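Swapping oxy for amino on a shared core

The source may report more compounds than this note shows. Statements on the series, on what has been measured and on what is new or still open speak of the compounds shown alone.

compound 1 `C/C=C(\C)C(=O)O[C@H]1C=CC(=O)O[C@H]1CCC(=O)[C@H](C)O`: 26000 nM
compound 2 `C/C=C(\C)C(=O)O[C@H]1C=CC(=O)O[C@H]1COC(=O)[C@H](C)O`: 19000 nM

Both were tested in a functional assay on A549 cells (Homo sapiens) for antiproliferative activity, read by sulforhodamine B assay, with a stated time of 48 h (a lower number here means a stronger inhibitor, a higher number a weaker inhibitor), and compound 2, at 19000 nM, stands within the scatter of compound 1. Compound 3 `C/C=C(\C)C(=O)O[C@H]1C=CC(=O)O[C@H]1CNC(=O)[C@H](C)O` carries ((1-hydroxyethyl)carbonyl)amino in place of ((1-hydroxyethyl)carbonyl)oxy on a saturated chain carbon bound to a saturated ring carbon. Among the compounds with values here, the one measured step bearing on this is a 1.4-fold lower number from compound 1 to compound 2 (0.14 log units; within the scatter), a swap at that same place. Within the data shown here, no measured compound carries the amino group, so the evidence is thin, and no step beyond the scatter is expected in this assay. The expected step is a 1.1-fold higher number from compound 2 to compound 3 (0.02 log units; within the scatter). For compound 3 the estimated value is 20000 nM, with a range of 9000 nM to 45000 nM.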

Compound 3, half-maximal inhibitory concentration: 27000 nM
Compound 3: the middle estimate sits 1.4-fold (0.13 log units) below what was measured; the range from low to high includes it.
By their numbers in this assay, from the lowest: compounds 2, 1 and 3 (each within the scatter of the next).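

Read in this assay, the amino link behaves like the two links before it, with a 1.4-fold higher number from compound 2 to compound 3 (0.15 log units; within the scatter) and a 1.0-fold higher number from compound 1 to compound 3 (0.02 log units; within the scatter). On a saturated chain carbon bound to a saturated ring carbon, the swap changes the group's count of hydrogen-bond donors and acceptors, yet the numbers stay within the scatter. Nothing available explains this result.

These compounds leave open whether any change here can move the number beyond the scatter. A longer chain or a carboxylic acid in place of the 1-hydroxyethyl part would test that.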